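The source may hold more compounds than are shown below. What is called first, only, known or untested is meant among the compounds shown, and "the series" means these compounds.

In an ADME assay on L929 cells (Mus musculus, culture collection number NCTC 929) for cytotoxicity, read by MTT assay, with a stated time of 72 h (on this read-out lower numbers stand for stronger inhibition and higher numbers for weaker inhibition), compound 1 `CCCCCCc1c(O)cc(C)oc1=O` gives > 200000 nM, which is a limit of the assay and not a number. In this assay, compound 2 `Cc1cc(O)c(C(=O)Nc2ccccc2)c(=O)o1` gives > 200000 nM, which is also a limit. Compound 1 therefore stands on (the limit of > 200000 nM in this assay, at which 2 of the 2 values shown sit), and no measured number places it more exactly.

The next compound to be tested is compound 3 `CCCCCCCCCCCCc1c(O)cc(C)oc1=O`. It keeps the core of compound 1 and extends the chain, with the change (hexyl in place of hydrogen on a saturated chain carbon, six bonds along the chain from an aromatic carbon). The same difference can also be read as methyl to heptyl.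

Going by the values given here, no measured step between closely related compounds is available to size this change, so any expectation for it is a judgement. A moderate shift towards stronger inhibition in this assay seems more likely than none, although another result at the limit would be no surprise. The expected change is an at least 1.6-fold lower number from compound 1 to compound 3 (0.22 log units; that floor lies within the scatter). For compound 3, the estimated value is 120000 nM, with an expected range of 30000 nM to 300000 nM.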

Compound 3, half-maximal inhibitory concentration: 57200 nM
The estimate for compound 3 lay 2.1-fold (0.32 log units) above the measured number, and the stated range covers the measured number.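

In this assay, hexyl in place of hydrogen on a saturated chain carbon, six bonds along the chain from an aromatic carbon, gives an at least 3.4-fold lower number from compound 1 to compound 3 (0.54 log units; beyond the scatter). Going by these compounds alone, this is the first sign that the chain on the shared core can move the read-out at all, since the earlier compounds offered only limits of the assay and no number to compare. From the compounds shown here alone, the step is a floor and not a full measure of the change, and its true size stays unknown, as compound 1 itself stands at a limit: the limit of > 200000 nM in this assay, at which 2 of the 3 values shown sit.

The compounds shown leave open how the number follows chain length, whether a chain of intermediate length already gives much of the shift and whether a longer chain than that of compound 3 lowers the number further. They also leave open whether the shift depends on an unbroken hydrocarbon chain, or whether a chain of the same length ending in a carboxylic acid or an amine would give a similar number.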